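Cytotoxicity notes on a dideoxynucleoside series

The compounds below may be only part of what the source reports. "The series", "measured", "known", "first", "only" and "open" are said of these compounds alone.

Measured so far:
compound 1 `Cc1cn([C@@H]2CC[C@H](CO)O2)c(=O)nc1N`: 950000 nM
compound 2 `O=c1nc(NO)ccn1[C@@H]1C=C[C@H](CO)O1`: 3500000 nM
compound 3 `Cc1cn([C@@H]2C=C[C@H](CO)O2)c(=O)nc1N`: 600000 nM

In an ADME assay on HL-60 cells (Homo sapiens) for cytotoxicity, read by MTT assay, with a stated time of 3 days (a lower number here means that less compound is tolerated, a higher number that more compound is tolerated), compound 1 stands second highest of the three numbers. Compound 3 lies within the scatter of compound 1, so no order is claimed between them; compound 2 gives a higher number, beyond the scatter. Compound 4 `Cc1cn([C@@H]2C[C@@H](F)[C@H](CO)O2)c(=O)nc1N` is not yet measured. It differs from compound 1 by fluoro in place of hydrogen on a saturated ring carbon, on a saturated ring carbon of a five-membered non-aromatic ring with one oxygen. For the measured compounds named here, no measured pair shows this change, so its effect is unknown here. The step of a 2.4-fold lower number from compound 1 to compound 4 (0.38 log units; beyond the scatter) is expected to be small, toward a lower number, and may fall within the scatter. For compound 4 the estimate is 400000 nM, range 80000 nM to 1500000 nM.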

Compound 4, half-maximal cytotoxic concentration: 1650000 nM
Estimate against measurement, compound 4: 4.1-fold (0.62 log units) below; measured number outside the range, above it.
By their numbers in this assay, from the lowest: compounds 3, 1 and 4 (each within the scatter of the next, the first and the last beyond it); then compound 2.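

The fluoro in place of hydrogen on this saturated ring carbon, next to the ring atom that bears a hydroxymethyl group, gives a 1.7-fold higher number from compound 1 to compound 4 (0.24 log units; within the scatter) in this assay and so produces no shift that can be told from scatter. This single pair shows that a fluoro at this place on the core of compound 1 leaves the reading unresolved from that of the parent. No measured property is at hand that bears on this result.

Going by these compounds, whether a hydroxyl, a chloro or an amine on the same ring carbon would move the number remains open. One pair also cannot show whether the fluoro behaves alike on the core of compound 3.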